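Fluoro-for-hydrogen step in a thiourea series with inactive parents

A few compounds are considered here, and "the series" means these few. Any claim that something is new, unique, unknown or untested is made for them only; others in the source may bear on it.

The series is tested in a functional assay on B16-F10 cells (Mus musculus) for cytotoxicity, read by MTT assay, with a stated time of 48 h; on this read-out higher numbers stand for weaker inhibition and lower numbers for stronger inhibition. Compound 1 has the structure `S=C(Nc1ccccc1)Nc1nc2c(Cl)cccc2s1`. In this assay compound 1 gives only a limit, > 50000 nM. Compound 3, `Fc1ccc(NC(=S)Nc2nc3c(Cl)cccc3s2)cc1`, is compound 1 with the change (fluoro in place of hydrogen on an aromatic carbon). In this assay compound 3 also gives only a limit, > 50000 nM. The step that the two limits leave unreadable from compound 1 to compound 3 therefore cannot be sized, as the limit of > 50000 nM in this assay, at which 3 of the 3 values shown sit, makes clear. Compound 2, `CCOc1ccc2nc(NC(=S)Nc3ccccc3)sc2c1`, carries a different core; the difference between the two cores is not broken down here. In this assay compound 2 gives only a limit, > 50000 nM. Compound 4, `CCOc1ccc2nc(NC(=S)Nc3ccc(F)cc3)sc2c1`, is still to be measured and stands to compound 2 as compound 3 stands to compound 1, namely through (fluoro in place of hydrogen on an aromatic carbon). The two place lines agree word for word, so this is the same change at the same kind of site. Going by the values given here, with the limit documented by the limit of > 50000 nM in this assay, at which 3 of the 3 values shown sit, as the only evidence, the step from compound 2 to compound 4 is expected to be unreadable as well, about a step that the limit leaves unreadable from compound 2 to compound 4. Compound 4 is expected to give roughly 80000 nM, between 40000 nM and 200000 nM, most likely reported only as a limit.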

Compound 4, half-maximal inhibitory concentration: > 50000 nM
Compound 4 gave a limit, no number; the forecaster's own chance of this, stated with the estimate: 85%; the middle value lies beyond the limit too.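

The fluoro-for-hydrogen step between compound 2 and compound 4 cannot be sized, because both compounds give only a limit in this assay: the limit of > 50000 nM in this assay, at which 4 of the 4 values shown sit.

The compounds shown leave open whether any member of this series gives a measurable value in this assay, and so whether going from phenyl to 4-fluorophenyl changes that value on either core.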